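The source may report more compounds than this note shows. Statements on the series, on what has been measured and on what is new or still open speak of the compounds shown alone.

Measured so far:
compound 1, `CCCCC[C@@H](C(=O)NCNC(=O)c1ccc(-c2ccc(C(=O)O)c(OCC)c2)o1)[C@@H](CC)N(O)C=O` — < 1 nM
compound 2, `CCCCC[C@@H](C(=O)NCNC(=O)c1cc2cccc(OC)c2o1)[C@@H](CC)N(O)C=O` — 126 nM
compound 3, `CCC[C@H](CN(O)C=O)C(=O)NCNC(=O)c1cc2cccc(OC)c2o1` — 1250 nM

All three were tested in an assay on CHO cells for inhibition of bone morphogenetic protein 1 (Homo sapiens), with stated times of 10 min and 60 min; a lower number here means a stronger inhibitor, a higher number a weaker inhibitor. For compound 1 the result is a limit of the assay rather than a number: it gives < 1 nM, and the limit of < 1 nM in this assay, at which 1 of the 3 values shown sits, shows that it is the only one of the three to sit there. Compound 2 gives 126 nM, and compound 3 gives 1250 nM, the higher number of these two and so the weaker inhibitor of the pair.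

The next compound, compound 4, `CCCCC[C@@H](C(=O)NCNC(=O)c1ccc(-c2ccccc2)o1)[C@@H](CC)N(O)C=O`, has not yet been measured. It differs from compound 1 in one place: a group of 6 heavy atoms (6 carbon; one six-membered aromatic ring of carbon only) in place of a group of 12 heavy atoms (9 carbon, 3 oxygen; one six-membered aromatic ring of carbon only), on an aromatic carbon. In words, a group of 6 heavy atoms (6 carbon; one six-membered aromatic ring of carbon only) takes the place of a group of 12 heavy atoms (9 carbon, 3 oxygen; one six-membered aromatic ring of carbon only), on an aromatic carbon. The hydrogen-bond donor and both acceptors of the departing group are gone.

Since compound 1 is known only as a limit, the size of the step cannot be fixed from the data; the expectation is a loss of potency beyond the scatter, estimated as an at least 30-fold higher number from compound 1 to compound 4 (1.47 log units; beyond the scatter). Compound 4 is thus expected at about 30 nM, in the range 3 nM to 300 nM.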

Compound 4, half-maximal inhibitory concentration: 32 nM
Compound 4: the middle estimate sits 1.1-fold (0.03 log units) below what was measured, and the stated range covers the measured number.
By their numbers in this assay, from the lowest: compound 4; then compound 2; then compound 3. At a limit, below all of these: compound 1.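

At this place, on an aromatic carbon next to the ring oxygen, the group clearly matters: in this assay, phenyl in place of the group of 12 heavy atoms, with its 1 hydrogen-bond donor and 2 hydrogen-bond acceptors, gives an at least 32-fold higher number from compound 1 to compound 4 (1.50 log units; beyond the scatter). Within the data shown here, this is the first step that can be read between measured compounds differing in one place, and it also shows that the plain phenyl still leaves compound 4 at 32 nM. The step has only a minimum size and its full size stays unknown, because the value of compound 1 is a limit of the assay and not a number: the limit of < 1 nM in this assay, at which 1 of the 4 values shown sits.

The compounds shown leave open which part of the departing group accounts for the step, since the carboxylic acid and the ethoxy group leave together, and a phenyl carrying only one of the two would separate them. They also leave open whether an amine or a hydroxyl group on the phenyl would have a similar effect to that of the carboxylic acid.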